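The compounds below may be only part of what the source reports. "The series", "measured", "known", "first", "only" and "open" are said of these compounds alone.

Within the data shown here, compound 1 `Cc1ccc(NC(=O)/C=C/C(=O)N2C/C(=C\c3ccc([N+](=O)[O-])cc3)C(=O)/C(=C/c3ccc([N+](=O)[O-])cc3)C2)cc1C` is one of three compounds measured so far. In a functional assay on Molt4/C8 cells (Homo sapiens) for cytotoxicity (on this read-out higher numbers stand for weaker inhibition and lower numbers for stronger inhibition), compound 1 gives 660 nM, level with compound 2 `Cc1ccc(NC(=O)/C=C/C(=O)N2C/C(=C\c3ccccc3)C(=O)/C(=C/c3ccccc3)C2)cc1`, which gives 660 nM, and together the two are the lowest of the three numbers. Compound 3 `COc1ccc(NC(=O)/C=C/C(=O)N2C/C(=C\c3ccccc3)C(=O)/C(=C/c3ccccc3)C2)cc1` gives 1100 nM, and the step of a 1.7-fold higher number from compound 2 to compound 3 (0.22 log units; within the scatter) is a small one. Compound 4 `O=C(/C=C/C(=O)N1C/C(=C\c2ccc([N+](=O)[O-])cc2)C(=O)/C(=C/c2ccc([N+](=O)[O-])cc2)C1)Nc1ccccc1` differs from compound 1 by phenyl in place of 3,4-dimethylphenyl on an amide-type nitrogen. Among the measured compounds shown here, the only measured step, from compound 2 to compound 3, stayed within the scatter, and no measured pair removes substituents altogether, so no shift beyond the scatter is expected and the step is estimated as a 1.2-fold higher number from compound 1 to compound 4 (0.08 log units; within the scatter) in this assay. Compound 4 is thus expected to give 800 nM, in a range from 350 nM to 1800 nM.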

Compound 4, half-maximal inhibitory concentration: 360 nM
Beside the measured number, compound 4's estimate is 2.2-fold (0.35 log units) above it, and the stated range covers the measured number.
By their numbers in this assay, from the lowest: compounds 4, 1, 2 and 3 (each within the scatter of the next, the first and the last beyond it).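

Replacing 3,4-dimethylphenyl with phenyl on the amide-type nitrogen gives a 1.8-fold lower number from compound 1 to compound 4 (0.26 log units; within the scatter) in this assay. Among these compounds, this is the first measured pair in which substituents on this aromatic ring are removed rather than exchanged, and on the core of compound 1 both methyl groups can go without a shift beyond the scatter. No measurement shown here explains the size of this step.

The compounds shown leave open whether an amine or a carboxylic acid on this phenyl would shift the number beyond the scatter.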